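The source may report more compounds than this note shows. Statements on the series, on what has been measured and on what is new or still open speak of the compounds shown alone.

Among the measured compounds shown here, compound 1 `COc1ccc(CCCCCCCCOc2ccc(CSCc3cccc(C(=O)O)c3)nc2/C=C/C(=O)O)cc1` gives 271 nM in a functional assay on the whole organism with Homo sapiens as the target (a higher number here means a weaker inhibitor, a lower number a stronger inhibitor), the lower of the two numbers measured so far; compound 2 `COc1ccc(CCCCCCCCOc2ccc(C[S+]([O-])Cc3cccc(C(=O)O)c3)nc2/C=C/C(=O)O)cc1` gives 2600 nM in this assay. For the measured compounds named here, the one measured step, a 9.6-fold higher number from compound 1 to compound 2 (0.98 log units; beyond the scatter), alters a different part of the molecule, so nothing measured speaks directly to shortening the chain. Compound 3 `COc1ccc(CCCCOc2ccc(CSCc3cccc(C(=O)O)c3)nc2/C=C/C(=O)O)cc1` differs from compound 1 by 4-methoxyphenyl in place of 4-(4-methoxyphenyl)butyl on a saturated chain carbon, four bonds along the chain from an oxygen on an aromatic ring. Without a measured step to guide the expectation, a modest weakening is expected, a 4.4-fold higher number from compound 1 to compound 3 (0.65 log units; beyond the scatter). Compound 3 is therefore estimated at 1200 nM, with a range from 250 nM to 6000 nM.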

Compound 3, half-maximal inhibitory concentration: 770 nM
The estimate for compound 3 lay 1.6-fold (0.19 log units) above the measured number; the range from low to high includes it.
By their numbers in this assay, from the lowest: compound 1; then compound 3; then compound 2.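

Shortening the chain, with 4-methoxyphenyl in place of 4-(4-methoxyphenyl)butyl on this saturated chain carbon, gives a 2.8-fold higher number from compound 1 to compound 3 (0.45 log units; beyond the scatter) in this assay and is the first measured change at this position. Of the two chain lengths shown, the longer one in compound 1 gives the lower number, and the difference is larger than the usual scatter. Nothing available explains this loss. On these data alone, whether a still longer chain would lower the number remains open, as does the effect of replacing the methoxy group with a fluorine atom or an amine.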